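This account rests on a few compounds, and the source may have more. Where it says the series, first, only, none or still open, it means among the compounds named here.

Compound 1, with the structure `CC(=O)OC/C1=C/C[C@](C)(CCC=C(C)C)/C=C/[C@@H](OC(=O)C=C(C)C)[C@](C)(O)/C=C/C1=O`, and compound 2, with the structure `CC(C)=CCC[C@]1(C)/C=C/[C@@H](OC(=O)C=C(C)C)[C@](C)(O)/C=C/C(=O)/C(C[Si](C)(C)C(C)(C)C)=C\C1`, share one core and differ at a single spot. In a functional assay on A549 cells (Homo sapiens) for antiproliferative activity, read by MTT assay, with a stated time of 48 h (a lower number here means a stronger inhibitor, a higher number a weaker inhibitor), compound 1 gives 2950 nM, while compound 2 gives 4200 nM. The step between them is a 1.4-fold higher number from compound 1 to compound 2 (0.15 log units; within the scatter), so the two values cannot be told apart by this measurement. Compound 2 therefore holds the higher of the two numbers, but only by a margin that repeat measurements would easily blur.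

Compound 3, with the structure `CCN(CC)C(=O)/C1=C/C[C@](C)(CCC=C(C)C)/C=C/[C@@H](OC(=O)C=C(C)C)[C@](C)(O)/C=C/C1=O`, is the next compound. Its change from compound 2 is a group of 7 heavy atoms (5 carbon, 1 nitrogen, 1 oxygen; no ring) in place of a group of 8 heavy atoms (7 carbon, 1 silicon; no ring), on a double-bonded ring carbon. Going by the values given here, no measured step alters this double-bonded ring carbon, and the one measured step, from compound 1 to compound 2, concerns a saturated chain carbon instead; it stayed within the scatter. Among the compounds with values here, there is thus no direct guide, and the only available comparison suggests that swapping groups near this part of the core need not move the number much. Compound 3 is expected to land close to compound 2, the estimated step being a 1.2-fold lower number from compound 2 to compound 3 (0.08 log units; within the scatter), in no clear direction. The estimate for compound 3 in this assay is 3500 nM, with a range from 1200 nM to 10000 nM.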

Compound 3, half-maximal inhibitory concentration: 11300 nM
Compound 3: middle estimate off by 3.2-fold (0.51 log units), on the low side; the whole stated range lies below it.
By their numbers in this assay, from the lowest: compounds 1 and 2 (each within the scatter of the next); then compound 3.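

In this assay, the group on this double-bonded ring carbon proves able to move the number: diethylcarbamoyl in place of acetoxymethyl gives a 3.8-fold higher number from compound 1 to compound 3 (0.58 log units; beyond the scatter), and diethylcarbamoyl in place of the silicon-bearing group gives a 2.7-fold higher number from compound 2 to compound 3 (0.43 log units; beyond the scatter). Both steps are modest but lie beyond the scatter, whereas exchanging acetoxymethyl for the silicon-bearing group gave only a 1.4-fold higher number from compound 1 to compound 2 (0.15 log units; within the scatter), which lies within it, and this makes the diethylcarbamoyl compound the weakest inhibitor of the three. No measurement available here accounts for the difference between diethylcarbamoyl and the other two groups.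

With one amide among these compounds, it remains open whether the weaker result goes with the carbonyl bound directly to the ring carbon or with the two ethyl groups on the nitrogen, and a dimethylcarbamoyl group or an unsubstituted carboxamide would help separate the two. It is also unknown how a carboxylic acid, a simple ester or an aminomethyl group would behave at this position.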